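A few compounds are considered here, and "the series" means these few. Any claim that something is new, unique, unknown or untested is made for them only; others in the source may bear on it.

Measured so far:
Compound 1 `CCNc1nc(C(=O)c2ccc(C)s2)c2sccc2n1` gives 1260 nM in a functional assay on CHO-K1 cells for antagonist activity at adenosine receptor A2b (Homo sapiens), read by FLIPR and calcium flux; on this read-out lower numbers stand for stronger inhibition and higher numbers for weaker inhibition.
Compound 2 `O=C(c1nccs1)c1nc(NCc2cccnc2)nc2ccsc12` gives 176 nM in this assay.

Compound 2 has the lowest of the two numbers, and its gap to compound 1 lies beyond the usual scatter of repeated measurements. Since the two compounds differ in more than one place, that gap cannot be tied to any single change.

Compound 3 `O=C(c1cccnc1)c1nc(NCc2cccnc2)nc2ccsc12` has not yet been measured. It differs from compound 2 in one place only: pyridin-3-yl in place of 1,3-thiazol-2-yl on a carbonyl carbon. Among the measured compounds shown here, no pair of measured compounds shows this same exchange, so there is no measured precedent for the step from compound 2 to compound 3. Both groups are small aromatic rings attached to the same carbonyl, and the rest of the molecule is unchanged, so a step of modest size, leaning toward a somewhat higher number, is expected rather than a large shift. The expected step is a 1.7-fold higher number from compound 2 to compound 3 (0.23 log units; within the scatter). In this assay compound 3 is expected to give about 300 nM, with a likely range from 100 nM to 1000 nM.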

Compound 3, half-maximal inhibitory concentration: 109 nM
Compound 3: the middle estimate sits 2.8-fold (0.44 log units) above what was measured, and the stated range covers the measured number.
By their numbers in this assay, from the lowest: compounds 3 and 2 (each within the scatter of the next); then compound 1.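

Among the compounds shown here, compound 2 and compound 3 give the first comparison that differs in one place only, and in this assay the exchange of 1,3-thiazol-2-yl for pyridin-3-yl on a carbonyl carbon gives a 1.6-fold lower number from compound 2 to compound 3 (0.21 log units; within the scatter) as its step, so the two compounds cannot be told apart. At this position, then, a six-membered aromatic ring with one hetero atom serves as well as a five-membered aromatic ring with two hetero atoms, even though the two rings differ in size and in their count of hydrogen-bond acceptors. No measurement at hand explains why the two rings read alike.

The compounds shown leave open whether this position needs an aromatic ring at all, which a plain phenyl ring or a saturated cyclohexyl group would help to test, and whether the place of the ring nitrogen matters, as pyridin-2-yl or pyridin-4-yl would show. The gap between these two compounds and compound 1 also remains unexplained, since compound 1 differs from each of them in more than one place.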